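A Smaller Aromatic Group on the Amine of Compound 1

The source may hold more compounds than are shown below. What is called first, only, known or untested is meant among the compounds shown, and "the series" means these compounds.

Among the compounds with values here, compound 1 `Nc1nc(NCc2ccccc2Cl)nc(-c2ccccc2CO)n1` is the more potent of the two compounds measured so far in a functional assay on cells for positive allosteric modulation of G-protein coupled receptor 68 (Homo sapiens), read by a luciferase reporter and cAMP accumulation, with a stated time of 30 min, at pH 6.8 and pH 8.3, in the presence of a further agent that is not named here (a lower number here means a less potent compound, a higher number a more potent compound, by a factor of ten per unit of this negative logarithm), where compound 1 gives 5.07. Within the data shown here, compound 2 `COc1ccccc1CNc1nc(N)nc(-c2ccccc2CO)n1` sits below it: in this assay compound 2 gives 3.99, and the step from compound 1 to compound 2 is a number 1.08 log units lower from compound 1 to compound 2 (beyond the scatter), the only change being a methoxy in place of chloro on an aromatic carbon. Compound 3 `Nc1nc(Nc2ccccc2)nc(-c2ccccc2CO)n1` has not yet been measured. It differs from compound 1 in one place: phenyl in place of 2-chlorobenzyl on a nitrogen on an aromatic ring. Among the measured compounds shown here, the step from compound 1 to compound 2 is the only measured guide, and it changed a different part of the same 2-chlorobenzyl group, so it bears on this step only loosely. Since that single change already moved the number by a large amount, and compound 3 loses the whole 2-chlorobenzyl, a step of similar size downward is expected, giving a number 0.77 log units lower from compound 1 to compound 3 (beyond the scatter). For compound 3 in this assay the estimate is 4.3, within a range from 3.6 to 5.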

Compound 3, negative logarithm of the antagonist equilibrium constant: 3.92
For compound 3 the middle estimate is 0.38 log units above the measured one; low and high end bracket the measured number.
By their numbers in this assay, from the lowest: compounds 3 and 2 (each within the scatter of the next); then compound 1.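

Replacing the whole 2-chlorobenzyl with phenyl on this nitrogen gives a number 1.15 log units lower from compound 1 to compound 3 (beyond the scatter) in this assay, so the group here matters not only through the substituent on its ring but also when the group as a whole is replaced. Compound 3 and compound 2 lie within the scatter of each other, which leaves compound 1, with its chlorine-bearing benzyl, as the only one of the three standing clear of the others. Nothing available explains this step.

Phenyl differs from 2-chlorobenzyl in two ways at once, lacking both the chlorine and the carbon that joins the ring to the nitrogen, so the share of each stays open. Plain benzyl and 2-chlorophenyl would separate the two, and a longer chain such as 2-chlorophenethyl would test the opposite direction.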